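A Benzyl Ester Added to a Series Without Measured Activity

A few compounds are considered here, and "the series" means these few. Any claim that something is new, unique, unknown or untested is made for them only; others in the source may bear on it.

Compound 1 `C=C[C@@](C)(/C=C/c1ccc(O)cc1)CC/C=C/C(=O)OCC` and compound 2 `C=C[C@@](C)(/C=C/c1ccc(O)cc1)CC/C=C/C(=O)OCc1ccccc1` share one core and differ in a single spot, (phenyl in place of methyl on a saturated chain carbon bound to an oxygen next to a carbonyl group). In a functional assay on HepG2 cells (Homo sapiens) for cytotoxicity, with a stated time of 72 h (a higher number here means that more compound is needed for the effect, a lower number that less compound is needed), compound 1 gives > 52000 nM, which is a limit of the assay rather than a number. Compound 2 likewise gives only a limit, > 52000 nM. The step that the two limits leave unreadable from compound 1 to compound 2 therefore cannot be sized. Compound 3 `C=C[C@@](C)(/C=C/c1ccc(O)cc1)CC/C=C(C)/C=C/C(=O)OCC` has a core whose difference from the core of compound 1 is not broken down here. In this assay compound 3 gives > 52000 nM, again a limit. Compound 4 `C=C[C@@](C)(/C=C/c1ccc(O)cc1)CC/C=C(C)/C=C/C(=O)OCc1ccccc1` carries the same change relative to compound 3, (phenyl in place of methyl on a saturated chain carbon bound to an oxygen next to a carbonyl group), at the same place. Because (the limit of > 52000 nM in this assay, at which 3 of the 3 values shown sit), the expected step that the limit leaves unreadable from compound 3 to compound 4 is small and most likely again unreadable. Compound 4 is thus estimated at 90000 nM, expected to fall between 30000 nM and 400000 nM.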

Compound 4, half-maximal effective concentration: > 52000 nM
Compound 4 ended at the assay's limit (the forecaster's own chance of this, stated with the estimate: 85%); the middle value does not contradict the limit.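

In this assay, among the compounds shown here, compound 3 and compound 4 each give only a limit, not a number, so no step between them can be read. The compounds shown leave open whether any change to the ester gives a readable value.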